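Two Trimethoxyphenyl Chalcone Pyrazoles and One Missing Methoxy

A few compounds are considered here, and "the series" means these few. Any claim that something is new, unique, unknown or untested is made for them only; others in the source may bear on it.

Compound 1 has the structure `COc1cc(-c2cc(/C=C/C(=O)c3ccc(N)cc3)[nH]n2)cc(OC)c1OC`. In a functional assay on SK-MEL-5 cells (Homo sapiens) for cytotoxicity, read by sulforhodamine B assay, with a stated time of 48 h, tested at 1 uM (a lower number here means a stronger effect, a higher number a weaker effect of the compound at the concentration tested), compound 1 gives 90%. Compound 2, with the structure `COc1ccc(-c2cc(/C=C/C(=O)c3ccc(N)cc3)[nH]n2)cc1OC`, differs from it in one place: hydrogen in place of methoxy on an aromatic carbon. In this assay compound 2 gives 94%, and the step of a number 4 percentage points higher from compound 1 to compound 2 (within the scatter) shows that this change left the read-out essentially where it was.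

Compound 3 has the structure `COc1cc(C(=O)/C=C/c2cc(-c3cc(OC)c(OC)c(OC)c3)n[nH]2)cc(OC)c1OC`. The difference between its core and the core of compound 1 is not broken down here. In this assay compound 3 gives 86%, which sits close to the other two values.

Compound 4, with the structure `COc1ccc(-c2cc(/C=C/C(=O)c3cc(OC)c(OC)c(OC)c3)[nH]n2)cc1OC`, has not yet been measured. It differs from compound 3 by the same change seen between compound 1 and compound 2: hydrogen in place of methoxy on an aromatic carbon. A small step, a number 4 percentage points higher from compound 3 to compound 4 (within the scatter), is expected, because the earlier step of a number 4 percentage points higher from compound 1 to compound 2 (within the scatter) was within the scatter. On that basis, compound 4 is expected to give about 90% in this assay, most likely between 78% and 98%.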

Compound 4, a percentage reported as activity, at one concentration (the size of the read-out at that concentration, not a potency): 87%
For compound 4 the middle estimate is 3 percentage points above the measured one, within the range that was stated.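

Replacing methoxy with hydrogen on the core of compound 3 gives a number 1 percentage points higher from compound 3 to compound 4 (within the scatter) in this assay, and this step can be set beside the earlier one on the other core: the same change on two cores in this assay, a number 4 percentage points higher (within the scatter) from compound 1 to compound 2 and a number 1 percentage points higher (within the scatter) from compound 3 to compound 4, 3 percentage points apart, within the scatter of two such steps. The two cores therefore agree, as neither step lies beyond the scatter and the steps do not differ from each other by more than the scatter allows. This does not show that the change would carry over in the same way wherever it has a clear effect, for all four compounds give close read-outs at one concentration, so the agreement rests on two small steps and says nothing about a large one.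

The compounds shown leave open what other groups would do at this place on the ring, such as a hydroxyl group, a chlorine atom or a longer chain like ethoxy. They also leave open whether the two cores would still agree at a higher concentration or in other cells.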